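Phenyl to methyl on the chain of compound 2

The source may report more compounds than this note shows. Statements on the series, on what has been measured and on what is new or still open speak of the compounds shown alone.

Compound 1 `CC(C)CNC(=O)n1c(=O)oc2cc(C3CCN(C)CC3)ccc21`: > 1 h, a limit
Compound 2 `CN1CCC(c2ccc3c(c2)oc(=O)n3C(=O)NCCCCc2ccccc2)CC1`: 0.667 h

Within the data shown here, in an ADME assay on microsomes from liver (Mus musculus) for metabolic stability, read by LC-MS, using NADPH, with stated times of 15 min and 60 min, tested at 4.6 uM (a higher number here means that the compound lasts longer, a lower number that the compound disappears faster), compound 2 holds the only actual number, and the other result is a limit. Compound 3 `CCCCCNC(=O)n1c(=O)oc2cc(C3CCN(C)CC3)ccc21` differs from compound 2 by methyl in place of phenyl on a saturated chain carbon, four bonds along the chain from an amide-type nitrogen. Among the measured compounds shown here, the one measured step bearing on this is an at least 1.4-fold lower number from compound 1 to compound 2 (0.17 log units; that floor lies within the scatter), with 3-phenylpropyl in place of isopropyl. That step gives only a floor. A small move towards a longer half-life is therefore expected, estimated as a 1.3-fold higher number from compound 2 to compound 3 (0.13 log units; within the scatter). The estimated half-life of compound 3 is 0.9 h, with an expected range of 0.5 h to 1.6 h.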

Compound 3, half-life: > 1 h
Compound 3 was reported as a limit (the forecaster's own chance of this, stated with the estimate: 40%); at least 1.1-fold (0.04 log units) between middle value and limit.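

In this assay, methyl in place of phenyl, four bonds along the chain from an amide-type nitrogen, gives an at least 1.4-fold higher number from compound 2 to compound 3 (0.17 log units; that floor lies within the scatter). Compound 3 is reported only as a limit, > 1 h. Among these compounds, this step isolates the phenyl at this place for the first time, but it gives only a floor, so the full size of the change stays unknown.

On these data alone, the step between compound 1 and compound 3 cannot be read because both values are the same limit: the limit of > 1 h in this assay, at which 2 of the 3 values shown sit. How an amine, a carboxylic acid or a longer chain would read at this place remains open.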